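Two Furan Ethers and an Untested Acid at the EP4 Receptor

The compounds below may be only part of what the source reports. "The series", "measured", "known", "first", "only" and "open" are said of these compounds alone.

The account begins with two measured compounds. Compound 1 `Cc1oc(C(=O)O)cc1COc1ccc(Oc2ccccc2)cc1` carries a carboxylic acid directly on the furan and gives 7% in an assay on cells for displacement of a labelled ligand from prostaglandin E2 receptor EP4 subtype (Homo sapiens), read by scintillation counting, tested at 10 uM; on this read-out higher numbers stand for more inhibition at the one concentration tested (going by the name of the read-out) and lower numbers for less inhibition. Compound 2 `CCOC(=O)c1cc(COc2ccc(-c3ccccc3)cc2)c(C)o1` carries an ethoxycarbonyl group in the same position and gives 15% in this assay. The two numbers lie within the usual scatter of each other, so compound 2 cannot be placed above or below compound 1 on this evidence; both register only weak displacement at the single concentration tested.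

Compound 3 `Cc1oc(CCC(=O)O)cc1COc1ccc(-c2ccccc2)cc1` is the next compound to be tested. It is built from the same atoms as compound 2, joined differently: 2-carboxyethyl in place of ethoxycarbonyl on an aromatic carbon. Going by the values given here, no step between measured compounds bears on this change, so the expectation rests on the weak signal of compound 2 alone.

The step from compound 2 to compound 3 is expected to be a number 1 percentage points lower from compound 2 to compound 3 (within the scatter), that is, no movement beyond the scatter in either direction. Compound 3 is therefore estimated at 14% in this assay, with a range from 2% to 35%.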

Compound 3, a percentage reported as inhibition, at one concentration (the size of the read-out at that concentration, not a potency): 63%
Compound 3: the middle estimate sits 49 percentage points below what was measured; measured number above the stated range.
By their numbers in this assay, from the lowest: compounds 1 and 2 (each within the scatter of the next); then compound 3.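

In this assay, going by these compounds alone, setting 2-carboxyethyl in place of ethoxycarbonyl on the aromatic carbon next to the ring oxygen gives a number 48 percentage points higher from compound 2 to compound 3 (beyond the scatter), the one step in this set that can be read as a real change. The two groups hold the same 5 heavy atoms, 3 carbon and 2 oxygen, and differ in how these are joined, with 1 hydrogen-bond donor in the entering group against none in the one that leaves, so this position of the shared core is shown to respond to the arrangement of those atoms and not only to their number. Nothing measured here accounts for the size of this rise, and no reason for it can be given from these compounds.

The step changes the ester into a free carboxylic acid and moves the carbonyl away from the ring in a single move, so the compounds shown leave open which of the two matters, a question that the ethyl ester of the same 2-carboxyethyl chain or a carboxymethyl group would bear on. They also leave open how a longer chain ending in a carboxylic acid, or a primary amide or an amine at the end of the chain, would read at this position.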